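Aryl substituent changes on a shared thromboxane antagonist core

A few compounds are considered here, and "the series" means these few. Any claim that something is new, unique, unknown or untested is made for them only; others in the source may bear on it.

Compound 2 `CC(=O)NCc1ccc(-c2ccc(COC3CC[C@H](N4CCCCCC4)[C@H]3OC/C=C\CCC(=O)O)cc2)cc1` in a functional assay for antagonist activity at thromboxane A2 receptor (Rattus norvegicus) (a higher number here means weaker binding, a lower number tighter binding), gives 20 nM. Compound 1 `O=C(O)CC/C=C\CO[C@H]1C(OCc2ccc(-c3ccccc3CCO)cc2)CC[C@@H]1N1CCCCCC1` gives in this assay 31.6 nM; the two numbers lie within the scatter of each other, so no ranking between compound 2 and compound 1 can be drawn. Among the compounds with values here, the single measured step, a 1.6-fold lower number from compound 1 to compound 2 (0.20 log units; within the scatter), shows that replacing the 2-(2-hydroxyethyl)phenyl group by the 4-(acetamidomethyl)phenyl group on the aromatic carbon left the dissociation constant essentially where it was.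

Compound 3 `O=C(O)CC/C=C\CO[C@H]1C(OCc2ccc(-c3ccccc3CO)cc2)CC[C@@H]1N1CCCCCC1` has not yet been measured. It differs from compound 2 by 2-(hydroxymethyl)phenyl in place of 4-(acetamidomethyl)phenyl on an aromatic carbon. Within the data shown here, the only measured step that bears on this change is the one from compound 1 to compound 2, which stayed within the scatter; the group entering in compound 3 closely resembles the 2-(2-hydroxyethyl)phenyl group of compound 1, shortened by one carbon in its side chain. Compound 3 is therefore expected to show no step beyond the scatter, an estimated change of a 1.5-fold higher number from compound 2 to compound 3 (0.18 log units; within the scatter). Compound 3 is estimated at 30 nM, with a range of 10 nM to 90 nM.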

Compound 3, dissociation constant: 6.31 nM
Compound 3: middle estimate off by 4.8-fold (0.68 log units), on the high side, and the stated range ends above it.
By their numbers in this assay, from the lowest: compound 3; then compounds 2 and 1 (each within the scatter of the next).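

On the aromatic carbon para to a large group, the earlier pair gave no separation, but this position does respond in this assay: a 3.2-fold lower number from compound 2 to compound 3 (0.50 log units; beyond the scatter) comes with 2-(hydroxymethyl)phenyl in place of 4-(acetamidomethyl)phenyl. The closer comparison changes only the side chain on the aryl group, and a 5.0-fold lower number from compound 1 to compound 3 (0.70 log units; beyond the scatter) comes with 2-(hydroxymethyl)phenyl in place of 2-(2-hydroxyethyl)phenyl, so the length of this hydroxyalkyl chain registers here, whereas the exchange of aryl groups between compound 1 and compound 2 stayed within the scatter. Both steps are modest, each rests on a single pair of compounds, and no measurement beyond these values is available to explain them.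

The compounds shown leave open whether the free hydroxy group is needed at all, which a 2-methylphenyl, 2-(methoxymethyl)phenyl or 2-carboxyphenyl group on the same aromatic carbon could test. They also leave open how the 2-(hydroxymethyl)phenyl group compares with its 4-(hydroxymethyl)phenyl isomer, and whether a longer chain such as 2-(3-hydroxypropyl)phenyl continues the trend from these two chain lengths.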